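A few compounds are considered here, and "the series" means these few. Any claim that something is new, unique, unknown or untested is made for them only; others in the source may bear on it.

Going by the values given here, compound 2 `COc1cc2c(Nc3nc4ccc(C(=O)Nc5c(C)cc(C)cc5C)cc4s3)ncnc2cc1OCCCN1CCCCC1C` holds the lowest of the two numbers so far in a functional assay on A549 cells (Homo sapiens) for cytotoxicity, read by WST assay, with a stated time of 72 h (on this read-out higher numbers stand for weaker inhibition and lower numbers for stronger inhibition), where compound 2 gives 5800 nM. Its nearest neighbour is compound 1 `COc1cc2c(Nc3nc4ccc(C(=O)Nc5c(C)cccc5C)cc4s3)ncnc2cc1OCCCN1CCCCC1C`, and in this assay compound 1 gives 75700 nM. Among the compounds with values here, the only measured step, a 13-fold lower number from compound 1 to compound 2 (1.12 log units; beyond the scatter), came from methyl in place of hydrogen on an aromatic carbon of the anilide part of the shared core.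

Compound 3 `COc1cc2c(Nc3nc4ccc(C(=O)Nc5c(C)cc(C)cc5C)cc4s3)ncnc2cc1OCCCN1CCCCC1` differs from compound 2 by hydrogen in place of methyl on a saturated ring carbon of a six-membered non-aromatic ring with one nitrogen, next to the ring nitrogen and next to the ring atom that bears a large group; read one bond further out, 2-methylpiperidin-1-yl becomes piperidin-1-yl. Within the data shown here, no measured step touches this ring, so the large step seen between compound 1 and compound 2 does not bear on it. Without any comparable change among the measured compounds, the expected step in this assay is no change at the digits printed from compound 2 to compound 3 (within the scatter), not beyond the scatter. Compound 3 is therefore estimated at 5800 nM, with a range from 2000 nM to 17000 nM.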

Compound 3, half-maximal inhibitory concentration: 10300 nM
Estimate against measurement, compound 3: 1.8-fold (0.25 log units) below; the range from low to high includes it.
By their numbers in this assay, from the lowest: compounds 2 and 3 (each within the scatter of the next); then compound 1.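

In this assay, replacing 2-methylpiperidin-1-yl with piperidin-1-yl gives a 1.8-fold higher number from compound 2 to compound 3 (0.25 log units; within the scatter) and so leaves compounds 2 and 3 indistinguishable, which shows that this methyl on a saturated ring carbon, next to the ring nitrogen, is not needed to hold the number at this level. Going by these compounds alone, this is the first measured step on this ring, and unlike the step on the anilide part, a 13-fold lower number from compound 1 to compound 2 (1.12 log units; beyond the scatter), it lies within the scatter, so in this small set a methyl matters at the aromatic carbon but makes no measurable difference at the saturated ring carbon. Nothing in the data at hand accounts for this result.

The compounds shown leave open whether the ring tolerates larger changes, such as a hydroxyl group or an ethyl group at this ring carbon, or replacement of the whole piperidine by morpholine or by an open-chain dimethylamino group. Within the data shown here, they also leave open whether the methyl on the aromatic carbon of the anilide part would have the same effect on a compound carrying piperidin-1-yl, since the only step for that change was read with 2-methylpiperidin-1-yl in place.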